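The compounds below may be only part of what the source reports. "The series", "measured", "known", "first", "only" and "open" are said of these compounds alone.

Of the compounds shown here, three built on one shared core have so far been tested in a functional assay on HuTu80 cells (Homo sapiens) for cytotoxicity, read by MTT assay, with a stated time of 72 h; a lower number here means that less compound is needed, a higher number that more compound is needed for the effect. Compound 1 `O=C1/C(=C\c2ccc(F)cc2)c2ccccc2N1c1c(Cl)cccc1Cl` gives 8 ug/mL. Compound 3 `O=C1/C(=C\c2ccccc2[N+](=O)[O-])c2ccccc2N1c1c(Cl)cccc1Cl` gives 10 ug/mL, the higher of the two numbers, though its nearest neighbour is compound 1 and the step of a 1.3-fold higher number from compound 1 to compound 3 (0.10 log units; within the scatter) stays within the scatter. Compound 2 `COc1ccc(/C=C2\C(=O)N(c3c(Cl)cccc3Cl)c3ccccc32)cc1` gives only > 100 ug/mL, which is a limit of the assay and not a number. That limit is the one described by the limit of > 100 ug/mL in this assay, at which 1 of the 3 values shown sits. The steps onto and off that limit are large: an at least 12-fold higher number from compound 1 to compound 2 (1.09 log units; beyond the scatter) and an at least 10-fold lower number from compound 2 to compound 3 (1.00 log units; beyond the scatter).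

Compound 4 `O=C1/C(=C\c2ccc(Cl)cc2)c2ccccc2N1c1c(Cl)cccc1Cl` has not yet been measured. The change from compound 3 is 4-chlorophenyl in place of 2-nitrophenyl on a double-bonded chain carbon bound to a double-bonded ring carbon. The step that bears most directly on it is a 1.3-fold higher number from compound 1 to compound 3 (0.10 log units; within the scatter), which shows that 4-fluorophenyl and 2-nitrophenyl give values within the scatter of each other; 4-chlorophenyl stands closer to 4-fluorophenyl than to the 4-methoxyphenyl of compound 2, whose limit lies far off. He therefore expects no step beyond the scatter, estimated as a 1.3-fold lower number from compound 3 to compound 4 (0.10 log units; within the scatter). For compound 4 he estimates 8 ug/mL, with a range from 3 ug/mL to 25 ug/mL.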

Compound 4, concentration for half-maximal effect: 6 ug/mL
For compound 4 the middle estimate is 1.3-fold (0.12 log units) above the measured one; the measured number falls inside the stated range.
By their numbers in this assay, from the lowest: compounds 4, 1 and 3 (each within the scatter of the next). At a limit, above all of these: compound 2.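

In this assay, compound 4 shows that a halogen larger than fluoro can stand on this aromatic carbon without a step beyond the scatter, a 1.3-fold lower number from compound 1 to compound 4 (0.12 log units; within the scatter), and that the 4-chlorophenyl and 2-nitrophenyl groups, on a double-bonded chain carbon bound to a double-bonded ring carbon, also stay within the scatter of each other, a 1.7-fold lower number from compound 3 to compound 4 (0.22 log units; within the scatter); a group with no hydrogen-bond acceptors thus reads like one that has them. The same aromatic carbon gives a second large step with methoxy, an at least 16-fold lower number from compound 2 to compound 4 (1.22 log units; beyond the scatter), so that among the four compounds shown only the 4-methoxyphenyl group of compound 2 stands apart, now against chloro as well as fluoro. The value of compound 2 is a limit of the assay and not a number: the limit of > 100 ug/mL in this assay, at which 1 of the 4 values shown sits.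

The compounds shown leave open whether the break seen with methoxy also appears with hydroxy, an amine or a longer chain such as ethoxy on that aromatic carbon. They also leave open how a carboxylic acid would read there, and whether any of these readings would hold in cells other than those of this assay.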